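The compounds below may be only part of what the source reports. "The series", "measured", "known", "first", "only" and "open" are said of these compounds alone.

Measured so far:
- compound 1, `CCSc1nc(=O)ccn1[C@@H]1O[C@H](COP(=O)(O)O)[C@@H](O)[C@H]1O`: 1500 nM in an in vitro functional assay on 1321-N1 cells for agonist activity at P2Y purinoceptor 2 (Homo sapiens), read by scintillation proximity assay and inositol phosphate accumulation; a lower number here means that less compound is needed, a higher number that more compound is needed for the effect
- compound 2, `CCCSc1nc(=O)ccn1[C@@H]1O[C@H](COP(=O)(O)OP(=O)(O)O)[C@@H](O)[C@H]1O`: 1200 nM in this assay

Compound 2 holds the lower of the two numbers, but the gap to compound 1 lies within the scatter, so the two cannot be told apart on these data. The unmeasured compound 3, `O=c1ccn([C@@H]2O[C@H](COP(=O)(O)OP(=O)(O)O)[C@@H](O)[C@H]2O)c(SCCc2ccccc2)n1`, differs from compound 2 by phenyl in place of methyl on a saturated chain carbon, two bonds along the chain from a sulfur. Within the data shown here, no comparable step is available here to size this change; a small shift, if any, toward a higher number is expected, a 1.7-fold higher number from compound 2 to compound 3 (0.22 log units; within the scatter). Compound 3 is estimated at 2000 nM, in the range 500 nM to 8000 nM.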

Compound 3, half-maximal effective concentration: 544 nM
Estimate against measurement, compound 3: 3.7-fold (0.57 log units) above; measured number inside the range.
By their numbers in this assay, from the lowest: compound 3; then compounds 2 and 1 (each within the scatter of the next).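

In this assay, among these compounds, phenyl in place of methyl on a saturated chain carbon, two bonds along the chain from a sulfur, gives a 2.2-fold lower number from compound 2 to compound 3 (0.34 log units; beyond the scatter) and is the only step readable so far. This position therefore accepts propylsulfanyl to phenethylsulfanyl, and the larger group goes with a modestly lower number, not a higher one. No measurement at hand accounts for the shift.

Going by these compounds, whether a cyclohexyl ring or a longer phenylpropyl chain at this place would act the same remains open. Among the compounds shown here, also open is whether the step carries over to the single phosphate of compound 1.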